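From fluoro to phenyl at the limit of the assay

The compounds below may be only part of what the source reports. "The series", "measured", "known", "first", "only" and "open" are said of these compounds alone.

Compound 1 `O=C(O)c1cc2cc(-c3ccc(Cl)cc3)ccc2n1O`: > 100000 nM
Compound 2 `O=C(O)c1cc2ccc(-c3ccc(F)cc3)cc2n1O`: > 100000 nM

Both entries come from an ADME assay on HS27 cells (Homo sapiens) for antiproliferative activity, read by sulforhodamine B assay, with a stated time of 48 h (on this read-out lower numbers stand for stronger inhibition and higher numbers for weaker inhibition), and each is a limit of the assay, not a number.

Compound 2 stands at the limit of > 100000 nM in this assay, at which 2 of the 2 values shown sit. No exact reading therefore exists for either measured compound.

The next compound to be tested is compound 3 `O=C(O)c1cc2ccc(-c3ccc(-c4ccccc4)cc3)cc2n1O`, which keeps the core of compound 2 and differs from it in one place: phenyl in place of fluoro on an aromatic carbon. Put simply, a phenyl group takes the place of fluoro on an aromatic carbon, para to a large group, so the new group brings one more six-membered aromatic ring.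

Within the data shown here, no measured pair shows what a change like this does in this assay, so any forecast is uncertain. The expectation leans on compound 2, whose > 100000 nM is a limit. Little or no gain in inhibition is expected, and the assay may well report a limit again. The expected change is an at least 1.1-fold lower number from compound 2 to compound 3 (0.04 log units; that floor lies within the scatter). For compound 3 the estimated value is 90000 nM, with an expected range from 35000 nM to 200000 nM.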

Compound 3, half-maximal inhibitory concentration: > 100000 nM
Compound 3 gave a limit, no number; the forecaster's own chance of this, stated with the estimate: 70%; at least 1.1-fold (0.04 log units) between middle value and limit.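

In this assay compound 3 gives > 100000 nM, which is a limit and not a number. Compound 2 also has only a limit, so no step can be read for phenyl in place of fluoro from compound 2 to compound 3. The compounds shown leave open how strongly any of them acts in this assay, and whether that swap changes it at all.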